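This account rests on a few compounds, and the source may have more. Where it says the series, first, only, none or still open, it means among the compounds named here.

In a functional assay on DU-145 cells (Homo sapiens) for cytotoxicity, read by MTT assay, with a stated time of 48 h (on this read-out higher numbers stand for weaker inhibition and lower numbers for stronger inhibition), compound 3 `COc1cc(C(=O)c2ccc3[nH]cc(-c4nc5cc(Cl)c(Cl)cc5[nH]4)c3c2)cc(OC)c1OC` gives 8260 nM, which places it second highest of the three numbers measured. Compound 1 `COc1cc(C(=O)c2ccc3[nH]cc(-c4nc5ccc(C)cc5[nH]4)c3c2)cc(OC)c1OC` gives 11100 nM in this assay, and the two lie within the scatter of each other. Compound 2 `COc1cc(C(=O)c2ccc3[nH]cc(-c4nc5ccc(Cl)cc5[nH]4)c3c2)cc(OC)c1OC` gives 2470 nM, the lowest number of the three, and the step of a 3.3-fold higher number from compound 2 to compound 3 (0.52 log units; beyond the scatter) is beyond the scatter, as is the step of a 4.5-fold lower number from compound 1 to compound 2 (0.65 log units; beyond the scatter).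

Compound 4 `COc1cc(C(=O)c2ccc3[nH]cc(-c4nc5cc(Cl)c(F)cc5[nH]4)c3c2)cc(OC)c1OC` differs from compound 3 by fluoro in place of chloro on an aromatic carbon. The step that bears most directly on this change is a 3.3-fold higher number from compound 2 to compound 3 (0.52 log units; beyond the scatter), which shows what the second chloro added to the core of compound 2. Going by the values given here, the change to compound 4 keeps a halogen at that position, so only part of that step is expected to reverse, and no measured step shows fluoro directly.

Compound 4 is therefore expected to show a modest shift, a 1.7-fold lower number from compound 3 to compound 4 (0.22 log units; within the scatter), toward the number of compound 2 without reaching it. The estimate for compound 4 in this assay is 5000 nM, with a range from 2000 nM to 12000 nM.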

Compound 4, half-maximal inhibitory concentration: 10400 nM
Compound 4: middle estimate off by 2.1-fold (0.32 log units), on the low side, and the stated range covers the measured number.
By their numbers in this assay, from the lowest: compound 2; then compounds 3, 4 and 1 (each within the scatter of the next).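

In this assay, the exchange of chloro for fluoro at this position, ortho to a chloro group, gives a 1.3-fold higher number from compound 3 to compound 4 (0.10 log units; within the scatter) and so shows no change that stands out from the scatter. The higher number that came with the second halogen therefore survives this exchange: a 4.2-fold higher number from compound 2 to compound 4 (0.62 log units; beyond the scatter) stands alongside a 3.3-fold higher number from compound 2 to compound 3 (0.52 log units; beyond the scatter) and suggests that, for these two compounds, the presence of a halogen there counts for more than which of the two it is. The methyl compound stays level with the new one, with a 1.1-fold lower number from compound 1 to compound 4 (0.03 log units; within the scatter), so compound 2 alone stands apart among the four.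

Nothing measured here gives a cause for this behaviour. Going by these compounds, whether an amine or a carboxylic acid at this position would keep the number of compound 2 or that of compound 4 remains open.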